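This account rests on a few compounds, and the source may have more. Where it says the series, first, only, none or still open, it means among the compounds named here.

Measured so far in an assay on membranes from CHO cells for displacement of a labelled ligand from adenosine receptor A1 (Homo sapiens), read by scintillation counting, with a stated time of 60 min, tested at 1 uM; on this read-out higher numbers stand for more inhibition at the one concentration tested (going by the name of the read-out) and lower numbers for less inhibition:
compound 1 `CC1=C(C(=O)CC(C)C)C(c2ccco2)NC(=O)N1` gives 16%
compound 2 `CC(=O)C1=C(C)NC(=O)NC1c1ccoc1` gives 6%
compound 3 `CCCC(=O)C1=C(C)NC(=O)NC1c1ccoc1` gives 1%

Compound 3 holds the lowest of the three numbers. Its nearest neighbour is compound 2, whose number lies within the scatter of it; the furthest is compound 1, whose higher number lies beyond the scatter. Among the compounds with values here, the one step known inside the series, a number 5 percentage points lower from compound 2 to compound 3 (within the scatter), is within the scatter, so the only change along a chain carbon bound to a carbonyl carbon that has been measured here left the read-out effectively unmoved.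

Compound 4 `CC1=C(C(=O)CC(C)C)C(c2ccoc2)NC(=O)N1` is the next member to be measured. Its relation to compound 3 is methyl in place of hydrogen on a saturated chain carbon bound to two saturated chain carbons. Within the data shown here, this is a further growth of the same chain, one bond beyond the place where compound 2 and compound 3 differ, so the step of a number 5 percentage points lower from compound 2 to compound 3 (within the scatter) is the one measured step that bears on it, and it was flat. Among the measured compounds shown here, compound 1, with 16%, carries no step to compound 4 that the data record, so its higher number cannot be set against the expectation. The step from compound 3 to compound 4 is therefore expected to be a number 4 percentage points higher from compound 3 to compound 4 (within the scatter), nothing beyond the scatter.

Compound 4 is accordingly estimated at 5%, with a range from 0% to 15%.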

Compound 4, a percentage reported as inhibition, at one concentration (the size of the read-out at that concentration, not a potency): 23%
Compound 4: middle estimate off by 18 percentage points, on the low side; measured number above the stated range.
By their numbers in this assay, from the lowest: compounds 3, 2, 1 and 4 (each within the scatter of the next, the first and the last beyond it).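

In this assay, within the data shown here, the change from propylcarbonyl to isobutylcarbonyl gives a number 22 percentage points higher from compound 3 to compound 4 (beyond the scatter) and is the first change on this chain to carry the number beyond the scatter, whereas the ethyl step gives only a number 5 percentage points lower from compound 2 to compound 3 (within the scatter) and stays within it. The position therefore responds to at least one substitution: isopropyl in place of hydrogen on the saturated chain carbon bound to a carbonyl carbon gives a number 17 percentage points higher from compound 2 to compound 4 (beyond the scatter) in this series, a size that ethyl at the same carbon does not reach. With the isobutylcarbonyl chain held constant, furan-3-yl in place of furan-2-yl on a saturated ring carbon gives a number 7 percentage points higher from compound 1 to compound 4 (within the scatter) and so does not separate the two furan attachments on this read-out.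

Still open, on these data alone, is whether a longer chain, a cyclopentyl ring or a terminal amine on this chain would take the number further, or whether the response is specific to the isobutylcarbonyl chain. No accompanying measurement bears on why this single methyl shifts the read-out.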